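Dichlorobenzyl Groups on a Sulfur and Cell Toxicity

This account rests on a few compounds, and the source may have more. Where it says the series, first, only, none or still open, it means among the compounds named here.

Compound 1 `Cn1cc(SCc2nnc(S)n2-c2c(Cl)cccc2Cl)c2ccccc21`: > 100000 nM
Compound 2 `Cn1cc(SCc2nnc(SCc3cc(Cl)ccc3Cl)n2-c2c(Cl)cccc2Cl)c2ccccc21`: > 100000 nM

In a toxicity assay on HEK-293T cells (Homo sapiens) for cytotoxicity, read by CCK-8 assay, with a stated time of 48 h (on this read-out lower numbers stand for higher toxicity in this test and higher numbers for lower toxicity in this test), compound 1 gives > 100000 nM, which is a limit of the assay rather than a number. Compound 2 is reported at > 100000 nM, again a limit. The step that the two limits leave unreadable from compound 1 to compound 2 therefore cannot be read, its size hidden by the two limits; both readings sit at the limit of > 100000 nM in this assay, at which 2 of the 2 values shown sit. Compound 3 `Cn1cc(SCc2nnc(SCc3c(Cl)cccc3Cl)n2-c2c(Cl)cccc2Cl)c2ccccc21` differs from compound 1 by 2,6-dichlorobenzyl in place of hydrogen on a sulfur. For the measured compounds named here, the only measured step that bears on this change is the one from compound 1 to compound 2, which made a comparable change on the same sulfur and left the reading at the limit. No step beyond the scatter is therefore expected here. Compound 3 is expected to give 150000 nM, with a range from 50000 nM to 500000 nM, most likely reported once more only as a limit. The step that the limit leaves unreadable from compound 1 to compound 3 is accordingly estimated to be small.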

Compound 3, half-maximal cytotoxic concentration: > 100000 nM
Compound 3 was reported as a limit (the forecaster's own chance of this, stated with the estimate: 85%); the middle value does not contradict the limit.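

In this assay compound 1, compound 2 and compound 3 all sit at a limit of the assay, so no step among them can be read: the limit of > 100000 nM in this assay, at which 3 of the 3 values shown sit.

The compounds shown leave open whether 2,5-dichlorobenzyl or 2,6-dichlorobenzyl on the sulfur changes toxicity in this assay at all, and whether the two groups differ.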